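Cytotoxicity Limits Across Three Amides and a Fourth Variant

The source may report more compounds than this note shows. Statements on the series, on what has been measured and on what is new or still open speak of the compounds shown alone.

Compound 1 `Cc1ccc(S(=O)(=O)N[C@@H](CC(=O)NC(C)(C)C)C(=O)NCCNC(=O)c2cc(Cl)ccc2Cl)cc1`: in an ADME assay on HepG2 cells (Homo sapiens) for cytotoxicity (a lower number here means that less compound is needed, a higher number that more compound is needed for the effect), compound 1 gives > 11000 nM, a limit of the assay.
Compound 2 `Cc1ccc(S(=O)(=O)N[C@@H](CC(=O)NC(C)(C)C)C(=O)NCCNC(=O)c2cc(Cl)ccn2)cc1`: in this assay compound 2 gives > 11000 nM, again a limit.
Compound 3 `Cc1ccc(S(=O)(=O)N[C@@H](CC(=O)NC(C)(C)C)C(=O)NCCNC(=O)c2ccc(F)cc2)cc1`: in this assay compound 3 gives > 11000 nM, also a limit.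

Among the measured compounds shown here, compound 3 therefore stands at the limit of > 11000 nM in this assay, at which 3 of the 3 values shown sit, where every value so far sits. Compound 4 `Cc1ccc(S(=O)(=O)N[C@@H](CC(=O)NC(C)(C)C)C(=O)NCCNC(=O)c2cc(C)ccn2)cc1` differs from compound 3 by 4-methylpyridin-2-yl in place of 4-fluorophenyl on a carbonyl carbon. The measured steps a step that the two limits leave unreadable from compound 1 to compound 2, a step that the two limits leave unreadable from compound 1 to compound 3 and a step that the two limits leave unreadable from compound 2 to compound 3 stay unreadable because the limit of > 11000 nM in this assay, at which 3 of the 3 values shown sit, hides their size, so no direction beyond the scatter can be derived. Compound 4 is expected near 20000 nM, in the range 11000 nM to 60000 nM. The step that the limit leaves unreadable from compound 3 to compound 4 is expected to be nominal only, most likely another limit.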

Compound 4, half-maximal effective concentration: > 11000 nM
Compound 4 was reported as a limit (the forecaster's own chance of this, stated with the estimate: 85%); the middle value does not contradict the limit.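

Among the compounds shown here, no step from compound 4 to compound 1, compound 2 or compound 3 can be read in this assay, because all four values are limits: the limit of > 11000 nM in this assay, at which 4 of the 4 values shown sit.

The compounds shown leave open how much of any of the four is needed for the effect, and whether the changes among them alter that amount.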